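Replacing a Methoxyphenyl Sulfonate Partner with Fluorophenyl

The source may report more compounds than this note shows. Statements on the series, on what has been measured and on what is new or still open speak of the compounds shown alone.

Compound 1 `COc1ccccc1OS(=O)(=O)c1ccc(N2CCN(C)C2=O)cc1` is the weaker of the two measured compounds: in a functional assay on M21 cells (Homo sapiens) for antiproliferative activity, read by sulforhodamine B assay, with a stated time of 48 h (on this read-out lower numbers stand for stronger inhibition and higher numbers for weaker inhibition), compound 1 gives 21000 nM, whereas compound 2 `COc1cc(OC)cc(OS(=O)(=O)c2ccc(N3CCN(C)C3=O)cc2)c1` gives 82 nM in this assay, a gap well beyond the scatter. Compound 3 `CN1CCN(c2ccc(S(=O)(=O)Oc3ccc(F)cc3)cc2)C1=O` has not yet been measured. It differs from compound 1 in one place: 4-fluorophenyl in place of 2-methoxyphenyl on an oxygen. Nothing measured shows how this exchange acts, so only a small step is expected, on the order of a 2.1-fold lower number from compound 1 to compound 3 (0.32 log units; beyond the scatter), toward a slightly lower number. Compound 3 is therefore estimated at 10000 nM in this assay, within a range of 2000 nM to 50000 nM.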

Compound 3, half-maximal inhibitory concentration: > 100000 nM
Compound 3: a limit, no number; the forecaster's own chance of this, stated with the estimate: 10%; middle value at least 10-fold (1.00 log units) away from the limit.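

In this assay, 4-fluorophenyl in place of 2-methoxyphenyl on an oxygen gives an at least 4.7-fold higher number from compound 1 to compound 3 (0.67 log units; beyond the scatter). This position is therefore sensitive to the exchange, and the change moves activity further down from an already weak starting point. The reading for compound 3 is a limit of the assay and not a number: the limit of > 100000 nM in this assay, at which 1 of the 3 values shown sits.

Going by these compounds, the true size of the step stays open, as does whether the fluorine or the loss of the methoxy group matters more. Also open, on these data alone, is how a phenyl ring carrying an amine or a carboxylic acid would behave on this oxygen.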